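Removing the core methoxy in a chromene series

A few compounds are considered here, and "the series" means these few. Any claim that something is new, unique, unknown or untested is made for them only; others in the source may bear on it.

Measured compounds:
compound 1 `COc1cc(Br)cc2c1OC(N)=C(C#N)C2CC(=O)c1ccccc1` with 99.1%
compound 2 `COc1cccc(C(=O)CC2C(C#N)=C(N)Oc3ccc(Br)cc32)c1` with 51.2%
compound 3 `COc1cc(Br)cc2c1OC(N)=C(C#N)C2CC(=O)c1ccc(C)cc1` with 116%

In a functional assay on MCF7 cells (Homo sapiens) for antiproliferative activity, read by sulforhodamine B assay, with a stated time of 72 h, tested at 10 uM (on this read-out higher numbers stand for a weaker effect at the one concentration tested and lower numbers for a stronger effect), compound 3 gives the highest of the three numbers. Going by the values given here, its nearest neighbour is compound 1, whose value in this assay is 99.1%, and the one step measured so far, a number 16.9 percentage points higher from compound 1 to compound 3 (beyond the scatter), is modest but beyond the scatter. Among the compounds with values here, compound 2, with 51.2% in this assay, sits furthest from compound 3; no single-change step links these two, so their values can only be set side by side.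

Compound 4 `Cc1ccc(C(=O)CC2C(C#N)=C(N)Oc3ccc(Br)cc32)cc1` is not yet measured. Compared with compound 3 it differs in one place: hydrogen in place of methoxy on an aromatic carbon. The group leaves from an aromatic carbon of the fused ring, meta to a bromo group. Within the data shown here, none of the measured steps touches this position; the only step, from a methyl entering on a different aromatic carbon, does not speak to a methoxy leaving the core. The estimate for compound 4 therefore rests mainly on compound 3, widened towards the lower values seen across the set, and the expected step is a number 24 percentage points lower from compound 3 to compound 4 (beyond the scatter). Compound 4 is expected to give about 92%, within 55% to 125%.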

Compound 4, a percentage reported as activity, at one concentration (the size of the read-out at that concentration, not a potency): 69%
Estimate against measurement, compound 4: 23 percentage points above, and the stated range covers the measured number.
By their numbers in this assay, from the lowest: compound 2; then compound 4; then compound 1; then compound 3.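

In this assay, going by these compounds alone, hydrogen in place of methoxy on the aromatic carbon meta to a bromo group gives a number 47 percentage points lower from compound 3 to compound 4 (beyond the scatter) towards a stronger effect at the one concentration tested, so this carbon, which no earlier step touched, has a large bearing on the read-out. The aryl group on the carbonyl still counts once the core methoxy is absent: 4-methylphenyl in place of 3-methoxyphenyl gives a number 17.8 percentage points higher from compound 2 to compound 4 (beyond the scatter) towards a weaker effect, and compound 2 keeps the lowest number of the four. No measurement at hand explains either step.

The compounds shown leave open whether the gain comes from losing the methoxy as such, since only hydrogen stands on this carbon in its place, and a hydroxyl group, an amine or a longer ether such as ethoxy there could tell more. They also leave open whether the same step would appear with the unsubstituted phenyl of compound 1, which would show if the effect of the core methoxy depends on the aryl group on the carbonyl.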